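The compounds below may be only part of what the source reports. "The series", "measured", "known", "first", "only" and "open" are said of these compounds alone.

Compound 1 `CC(C)NCCS(=O)(=O)NC(=O)c1ccc(Nc2nc(NC3(c4ccc(Cl)cc4)CC3)nc(OCC(F)(F)F)n2)cc1`: 89%
Compound 2 `CC(C)(C)NC(=O)NCCS(=O)(=O)NC(=O)c1ccc(Nc2nc(NC3(c4ccc(Cl)cc4)CC3)nc(OCC(F)(F)F)n2)cc1`: 96%
Compound 3 `CCS(=O)(=O)NC(=O)c1ccc(Nc2nc(NC3(c4ccc(Cl)cc4)CC3)nc(OCC(F)(F)F)n2)cc1`: 100%

These three compounds share one core and were measured in an ADME assay on microsomes from liver (Homo sapiens) for metabolic stability, with a stated time of 10 min; on this read-out lower numbers stand for a less stable compound and higher numbers for a more stable compound. Compound 3 stands beyond the scatter above compound 1, with a number 11 percentage points higher from compound 1 to compound 3 (beyond the scatter), whereas its gap to compound 2, a number 4 percentage points higher from compound 2 to compound 3 (within the scatter), is within the scatter. Compound 4 `CC(C)NC(=O)NCCS(=O)(=O)NC(=O)c1ccc(Nc2nc(NC3(c4ccc(Cl)cc4)CC3)nc(OCC(F)(F)F)n2)cc1` is not yet measured; it differs from compound 3 by (isopropylcarbamoyl)amino in place of hydrogen on a saturated chain carbon, two bonds along the chain from a sulfonyl sulfur. The step from compound 2 to compound 3 removed a closely related group from the same place and stayed within the scatter, so the reverse direction taken here is expected to change little. Compound 4 is therefore expected to show a number 6 percentage points lower from compound 3 to compound 4 (within the scatter), a shift within the scatter. The estimate for compound 4 in this assay is 94%, with a range from 85% to 100%.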

Compound 4, percent of the compound remaining: 100%
Beside the measured number, compound 4's estimate is 6 percentage points below it, within the range that was stated.
By their numbers in this assay, from the lowest: compounds 1, 2, 3 and 4 (each within the scatter of the next, the first and the last beyond it).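

The chain carbon two bonds along from the sulfonyl sulfur carries (isopropylcarbamoyl)amino without loss in this assay, with no change at the digits printed from compound 3 to compound 4 (within the scatter) as the step from hydrogen. Trading tert-butyl for isopropyl on that carbamoyl group also matters little, giving a number 4 percentage points higher from compound 2 to compound 4 (within the scatter) as the step. Placing the carbamoyl on the amine nitrogen gives a number 11 percentage points higher from compound 1 to compound 4 (beyond the scatter) as the step, although the related tert-butyl step from compound 1 to compound 2 stays within the scatter.

On these data alone, a carboxylic acid or a longer chain at this carbon remains open. Nothing shown gives a reason for these numbers.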